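Ethyl for Methyl on the Chain of Compound 1

The compounds below may be only part of what the source reports. "The series", "measured", "known", "first", "only" and "open" are said of these compounds alone.

All three measured compounds share one core and differ only in the group attached to an aromatic nitrogen. Compound 1 `C[C@H](Nc1ncnc2[nH]cnc12)c1nn(-c2cccnc2)c2cc(F)ccc12` carries pyridin-3-yl there, and in a functional assay on Bel-7402 cells (Homo sapiens) for inhibition, read by sulforhodamine B assay, with a stated time of 72 h, tested at 10 uM (a lower number here means less inhibition, a higher number more inhibition at the concentration tested (going by the name of the read-out)), compound 1 gives 8%, the highest of the three numbers. Compound 2 `C[C@H](Nc1ncnc2[nH]cnc12)c1nn(-c2ccc(C#N)cc2)c2cc(F)ccc12` has 4-cyanophenyl in its place; in this assay compound 2 gives 0%, and the step of a number 8 percentage points lower from compound 1 to compound 2 (within the scatter) stays within the scatter. Compound 3 `C[C@H](Nc1ncnc2[nH]cnc12)c1nn(-c2cccc(S(C)(=O)=O)c2)c2cc(F)ccc12` bears 3-(methylsulfonyl)phenyl; in this assay compound 3 gives -16%. The steps of a number 24 percentage points lower from compound 1 to compound 3 (beyond the scatter) and a number 16 percentage points lower from compound 2 to compound 3 (beyond the scatter) are modest but beyond the scatter.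

Compound 4 `CC[C@H](Nc1ncnc2[nH]cnc12)c1nn(-c2cccnc2)c2cc(F)ccc12` is not yet measured. It keeps the pyridin-3-yl of compound 1 and changes a different place: methyl in place of hydrogen on a saturated chain carbon, two bonds along the chain from an aromatic carbon and a nitrogen on an aromatic ring. Going by the values given here, no measured step touches this saturated chain carbon; every step so far moves the group on the aromatic nitrogen, so the measured steps give no guide to this change, and the low inhibition seen for compound 1 is the only anchor. The expectation for this assay is therefore a step of no size beyond the scatter, no change at the digits printed from compound 1 to compound 4 (within the scatter), in either direction. For compound 4 the estimate in this assay is 8%, within a range from -10% to 25%.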

Compound 4, a percentage reported as inhibition, at one concentration (the size of the read-out at that concentration, not a potency): 12%
Compound 4: the middle estimate sits 4 percentage points below what was measured; the measured number falls inside the stated range.
By their numbers in this assay, from the lowest: compound 3; then compounds 2, 1 and 4 (each within the scatter of the next, the first and the last beyond it).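

Going by these compounds alone, the saturated chain carbon is touched here for the first time, and in this assay the methyl to ethyl change on it gives a number 4 percentage points higher from compound 1 to compound 4 (within the scatter), so this one added carbon produces no difference that can be told apart from the scatter. Inhibition is low at the concentration tested on both sides of this step, which means that ethyl on the chain, with pyridin-3-yl kept on the aromatic nitrogen, does not lift the compound out of the low range seen so far. No measurement shown here offers an explanation for this result.

From the compounds shown here alone, whether a longer chain such as propyl, or an amine or a hydroxyl group on this same carbon, would move the number beyond the scatter remains open. Also open is whether ethyl in this place would read the same with 4-cyanophenyl or 3-(methylsulfonyl)phenyl on the aromatic nitrogen, since the one step shown pairs it only with pyridin-3-yl.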